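The compounds below may be only part of what the source reports. "The series", "measured", "known", "first", "only" and "open" are said of these compounds alone.

Compound 3 `CC[C@H](C)[C@@H]1C(=O)N[C@H](C2Cc3ccccc3C2)C(=O)N1[C@@H](C(=O)NC)c1cc(C)cnc1C` is the point of departure. Going by the values given here, in an in vitro ADME assay on microsomes from liver (Macaca fascicularis) for metabolic stability (a lower number here means slower removal, a higher number faster removal of the compound), compound 3 gives 5 mL.min-1.g-1, the lowest of the three numbers measured so far. Compound 2 `CC[C@@H](C)[C@@H]1C(=O)N[C@H](C2Cc3ccccc3C2)C(=O)N1[C@@H](C(=O)N1CCOCC1)c1ccc(C)nc1` gives 8 mL.min-1.g-1 in this assay, a number that sits within the scatter of the number for compound 3, so the two cannot be told apart. Among the compounds with values here, compound 1 `CC[C@H](C)[C@@H]1C(=O)N[C@H](C2Cc3ccccc3C2)C(=O)N1[C@@H](C(=O)N(C)C)c1cc(C)cnc1C` gives 13 mL.min-1.g-1 in this assay, and the step of a 2.6-fold lower number from compound 1 to compound 3 (0.41 log units; beyond the scatter) is the one measured change that lies beyond the scatter.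

Compound 4 `CC[C@H](C)[C@@H]1C(=O)N[C@H](C2Cc3ccccc3C2)C(=O)N1[C@@H](C(=O)NC)c1cnc(C)cc1C` is the untested compound; it differs from compound 3 in one place (4,6-dimethylpyridin-3-yl in place of 2,5-dimethylpyridin-3-yl on a saturated chain carbon bound to an amide-type nitrogen in a ring and a carbonyl carbon). The two compounds hold the same atoms, joined differently. Within the data shown here, the one measured step, a 2.6-fold lower number from compound 1 to compound 3 (0.41 log units; beyond the scatter), concerns a different place, the amide-type nitrogen, and compound 1 and compound 2 differ from each other in more than one place, so no measured step speaks directly to swapping 2,5-dimethylpyridin-3-yl for 4,6-dimethylpyridin-3-yl. Among the measured compounds shown here, with no comparable step to lean on, no change beyond the scatter is expected in this assay, and the expected step is no change at the digits printed from compound 3 to compound 4 (within the scatter). Compound 4 is therefore estimated at 5 mL.min-1.g-1, with a range from 2.5 mL.min-1.g-1 to 10 mL.min-1.g-1.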

Compound 4, intrinsic clearance in microsomes: 20 mL.min-1.g-1
Beside the measured number, compound 4's estimate is 4.0-fold (0.60 log units) below it; measured number above the stated range.
By their numbers in this assay, from the lowest: compounds 3, 2, 1 and 4 (each within the scatter of the next, the first and the last beyond it).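

Replacing 2,5-dimethylpyridin-3-yl with 4,6-dimethylpyridin-3-yl gives a 4.0-fold higher number from compound 3 to compound 4 (0.60 log units; beyond the scatter) in this assay, so with the atom count unchanged, how those atoms are joined still matters at this place. Going by these compounds alone, until now the only step beyond the scatter lay on the amide-type nitrogen, a 2.6-fold lower number from compound 1 to compound 3 (0.41 log units; beyond the scatter) and this result adds the group on the saturated chain carbon as a second place where the number moves beyond the scatter. The information at hand offers nothing that accounts for the higher number of compound 4.

The two groups differ in where both methyl groups and the ring nitrogen stand, so this single step cannot show which of these changes matters, or whether the same swap would give a comparable step on the dimethyl amide of compound 1. The compounds shown also leave open how a pyridin-3-yl ring with no methyl groups, or a phenyl ring carrying two methyl groups, would behave at this place in this assay and whether either would stay nearer to compound 3 or to compound 4.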